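The compounds below may be only part of what the source reports. "The series", "measured", "known", "first", "only" and "open" are said of these compounds alone.

In a toxicity assay on L02 cells (Homo sapiens) for cytotoxicity, read by MTT assay, with a stated time of 72 h (a higher number here means a weaker inhibitor, a lower number a stronger inhibitor), compound 2 (`CN1CCN(CCCn2c3c(c4ccccc42)C(=O)c2c[n+]([O-])c4ccccc4c2C3=O)CC1`) gives 230 nM, the lower of the two measured numbers, while compound 1 (`O=C1c2c[n+]([O-])c3ccccc3c2C(=O)c2c1c1ccccc1n2Cc1cn(C[C@H](O)CO)nn1`) gives 1130 nM. Compound 3 (`O=C1c2c[n+]([O-])c3ccccc3c2C(=O)c2c1c1ccccc1n2CCN1CCCCC1`) differs from compound 2 by piperidin-1-yl in place of (4-methylpiperazin-1-yl)methyl on a saturated chain carbon, two bonds along the chain from an aromatic nitrogen. Within the data shown here, the one measured step that bears on this chain, a 4.9-fold lower number from compound 1 to compound 2 (0.69 log units; beyond the scatter), was modest and introduced the 4-methylpiperazin-1-yl ring. Compound 3 loses that ring but still carries a six-membered non-aromatic ring, so no change beyond the scatter is expected. The expected step is a 1.3-fold higher number from compound 2 to compound 3 (0.10 log units; within the scatter). For compound 3 the estimated value is 290 nM, with an expected range of 100 nM to 850 nM.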

Compound 3, half-maximal inhibitory concentration: 1050 nM
Beside the measured number, compound 3's estimate is 3.6-fold (0.56 log units) below it, and the stated range ends below it.
By their numbers in this assay, from the lowest: compound 2; then compounds 3 and 1 (each within the scatter of the next).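

In this assay, the change from 3-(4-methylpiperazin-1-yl)propyl to 2-(piperidin-1-yl)ethyl is not neutral, with a 4.6-fold higher number from compound 2 to compound 3 (0.66 log units; beyond the scatter). The other new step, a 1.1-fold lower number from compound 1 to compound 3 (0.03 log units; within the scatter), shows that a six-membered non-aromatic ring on this chain does not by itself keep the low number of compound 2. Nothing available explains this difference.

Going by these compounds, it remains open whether the chain length or the methyl-bearing second ring nitrogen accounts for the gap: 3-(piperidin-1-yl)propyl and 2-(4-methylpiperazin-1-yl)ethyl on the shared core would separate the two.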